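Vero cytotoxicity notes on an aryl amide series

The compounds below may be only part of what the source reports. "The series", "measured", "known", "first", "only" and "open" are said of these compounds alone.

Values in an ADME assay on Vero cells (Chlorocebus sabaeus) for cytotoxicity, read by MTT assay, with a stated time of 72 h; on this read-out higher numbers stand for lower toxicity in this test and lower numbers for higher toxicity in this test:

compound 1 `COC(=O)c1cc(-c2cccc(NC(=O)c3ccc(/C=C/C(=O)c4cccc(F)c4)cc3)c2)on1`: > 40 ug/mL
compound 2 `COC(=O)c1cc(-c2cccc(NC(=O)c3ccc(C4OC4C(=O)c4ccc(Cl)cc4)cc3)c2)on1`: > 20 ug/mL
compound 3 `COC(=O)c1cc(-c2cccc(NC(=O)c3ccc(/C=C/C(=O)c4ccc(Cl)cc4)cc3)c2)on1`: > 50 ug/mL

Compound 3 stands only at a limit of this assay, not at a number. The same holds for compound 1 and compound 2, each sitting at its own limit (the limit of > 20 ug/mL in this assay, at which 1 of the 3 values shown sits, (the limit of > 40 ug/mL in this assay, at which 1 of the 3 values shown sits), (the limit of > 50 ug/mL in this assay, at which 1 of the 3 values shown sits)), so none of the three steps among them can be read: a step that the two limits leave unreadable from compound 1 to compound 2, a step that the two limits leave unreadable from compound 1 to compound 3, a step that the two limits leave unreadable from compound 2 to compound 3.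

Compound 4 `COC(=O)c1cc(-c2cccc(NC(=O)c3ccc(/C=C/C(=O)c4cccc(OC)c4)cc3)c2)on1` differs from compound 3 by 3-methoxyphenyl in place of 4-chlorophenyl on a carbonyl carbon. Among the compounds with values here, the only measured step at that same carbonyl carbon is the one from compound 1 to compound 3, and it is unreadable; no measured step therefore sets a size or direction for this change in this assay.

Within the data shown here, with every value so far at a limit, the expectation for compound 4 is a step of no readable size, a step that the limit leaves unreadable from compound 3 to compound 4, and a value again most likely reported as a limit. Compound 4 is estimated at 60 ug/mL, with a range from 30 ug/mL to 120 ug/mL.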

Compound 4, half-maximal cytotoxic concentration: > 100 ug/mL
Compound 4: no number, only a limit; the forecaster's own chance of this, stated with the estimate: 70%; middle value at least 1.6-fold (0.22 log units) from the limit.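

Compound 4 also stands only at a limit in this assay: the limit of > 100 ug/mL in this assay, at which 1 of the 4 values shown sits.

Within the data shown here, no step from compound 1, compound 2 or compound 3 to compound 4 can be read. Still open, going by these compounds, is the actual cytotoxic concentration of all four compounds, and whether 3-methoxyphenyl in place of 4-chlorophenyl changes it at all.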